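Moving the Basic Piperazine One Bond Outward

The compounds below may be only part of what the source reports. "The series", "measured", "known", "first", "only" and "open" are said of these compounds alone.

Among the measured compounds shown here, compound 2 `COc1cc(C)c(S(=O)(=O)N(C)CCOCC(=O)N2CCC(N3CCN(C(C)C)CC3)CC2)c(C)c1` gives 3.8 nM in an assay on HEK293 cells for displacement of a labelled ligand from B1 bradykinin receptor (Homo sapiens), read by scintillation counting (on this read-out higher numbers stand for weaker inhibition and lower numbers for stronger inhibition), and stands as the lowest of the three numbers measured so far. Compound 1 `COc1cc(C)c(S(=O)(=O)N(C)CCOCC(=O)N2CCC(C(C)(C)CN(C)C)CC2)c(C)c1`, which carries 1-((dimethylamino)methyl)-1-methylethyl on the same saturated ring carbon, gives 10 nM in this assay. Compound 3 `Cc1c(Cl)ccc(S(=O)(=O)N(C)CC(=O)NCC(=O)N(C)Cc2ccc(C3=NCCN3)cc2)c1Cl`, built on a different core, gives 78 nM in this assay and lies furthest from compound 2.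

Compound 4 `COc1cc(C)c(S(=O)(=O)N(C)CCOCC(=O)N2CCC(CN3CCN(C)CC3)CC2)c(C)c1` has not yet been measured. It differs from compound 2 in one place: (4-methylpiperazin-1-yl)methyl in place of 4-isopropylpiperazin-1-yl on a saturated ring carbon. For the measured compounds named here, the only measured step that bears on this change is a 2.6-fold lower number from compound 1 to compound 2 (0.42 log units; beyond the scatter), which shows that exchanging one basic group for another on this saturated ring carbon shifted the number by a modest amount. Compound 4 keeps a piperazine and a basic nitrogen like compound 2, while the methylene linker and the smaller methyl group leave it between compound 1 and compound 2 in shape. A step no larger than the usual scatter is therefore expected, if anything toward a slightly higher number. Compound 4 is estimated to give about 6 nM in this assay, with a range from 2 nM to 18 nM. The expected step is a 1.6-fold higher number from compound 2 to compound 4 (0.20 log units; within the scatter).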

Compound 4, inhibition constant: 4.7 nM
For compound 4 the middle estimate is 1.3-fold (0.11 log units) above the measured one; low and high end bracket the measured number.
By their numbers in this assay, from the lowest: compounds 2 and 4 (each within the scatter of the next); then compound 1; then compound 3.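

In this assay the change on this saturated ring carbon gives a 1.2-fold higher number from compound 2 to compound 4 (0.09 log units; within the scatter) and so does not separate (4-methylpiperazin-1-yl)methyl from 4-isopropylpiperazin-1-yl, although the two groups differ both in the methylene link to the ring and in the alkyl group on the piperazine. The gap to the earlier group also holds for the new one, with a 2.1-fold lower number from compound 1 to compound 4 (0.33 log units; beyond the scatter) alongside a 2.6-fold lower number from compound 1 to compound 2 (0.42 log units; beyond the scatter) on the same carbon, so among these three compounds both piperazine groups give lower numbers than 1-((dimethylamino)methyl)-1-methylethyl. Nothing available here accounts for the two piperazine groups reading alike or for their gap to the group of compound 1.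

As far as these compounds go, what 4-methylpiperazin-1-yl or (4-isopropylpiperazin-1-yl)methyl would give at this carbon remains open, so the methylene link and the alkyl group on the piperazine cannot yet be weighed separately. From the compounds shown here alone, it also remains open whether a morpholine or a carboxylic acid on the same carbon would stay in this range of numbers.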